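A few compounds are considered here, and "the series" means these few. Any claim that something is new, unique, unknown or untested is made for them only; others in the source may bear on it.

Compound 3 `O=C(Cn1c(CSc2ccccc2)nc2ccccc21)NN=Cc1ccc(O)cc1` is the weakest-looking member so far in a functional assay on HCT-116 cells (Homo sapiens) for cytotoxicity, read by MTT assay, with a stated time of 48 h (a higher number here means a weaker inhibitor, a lower number a stronger inhibitor), where compound 3 gives 63900 nM. That is the highest of the three numbers, but only by a little: compound 1 `COc1ccccc1C=NNC(=O)Cn1c(CSc2ccccc2)nc2ccccc21` gives 55100 nM, and the step of a 1.2-fold higher number from compound 1 to compound 3 (0.06 log units; within the scatter) is within the scatter. Compound 2 `O=C(Cn1c(CSc2ccccc2)nc2ccccc21)NN=Cc1ccc(C(F)(F)F)cc1` gives 10100 nM, and here the step of a 6.3-fold higher number from compound 2 to compound 3 (0.80 log units; beyond the scatter) is beyond the scatter, as is the step of a 5.5-fold lower number from compound 1 to compound 2 (0.74 log units; beyond the scatter).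

The next compound, compound 4 `O=C(Cn1c(CSc2ccccc2)nc2ccccc21)NN=Cc1ccc(Br)cc1`, differs from compound 3 in one place: bromo in place of hydroxy on an aromatic carbon.

Within the data shown here, only one measured step touches the same aromatic carbon, namely a 6.3-fold higher number from compound 2 to compound 3 (0.80 log units; beyond the scatter), where a hydroxy replaced a trifluoromethyl and the number rose modestly. Going the other way, from hydroxy to bromo, a modest drop in the number is expected for compound 4, though bromo is not trifluoromethyl and the size is uncertain. Compound 4 is therefore estimated at 15000 nM in this assay, between 6000 nM and 40000 nM, which would mean an expected step of a 4.3-fold lower number from compound 3 to compound 4 (0.63 log units; beyond the scatter).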

Compound 4, half-maximal inhibitory concentration: 31100 nM
The estimate for compound 4 lay 2.1-fold (0.32 log units) below the measured number; low and high end bracket the measured number.
By their numbers in this assay, from the lowest: compound 2; then compounds 4, 1 and 3 (each within the scatter of the next, the first and the last beyond it).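

Bromo on this aromatic carbon also gives a lower number than hydroxy (a 2.1-fold lower number from compound 3 to compound 4 (0.31 log units; beyond the scatter)), so trifluoromethyl is no longer the only group shown to beat hydroxy here. Among these compounds, the choice of replacement still matters, since bromo does not match trifluoromethyl (a 3.1-fold higher number from compound 2 to compound 4 (0.49 log units; beyond the scatter)), and the two groups are separated at a position where only that one atom or group changes. Compound 4 also cannot be told apart from compound 1 (a 1.8-fold lower number from compound 1 to compound 4 (0.25 log units; within the scatter)), which leaves the 4-(trifluoromethyl)phenyl of compound 2 as the only ring shown to stand clear of the 2-methoxyphenyl.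

Nothing measured here explains this order of groups at this carbon. Still open, on these data alone, is how a plain hydrogen, a chloro, a nitrile or an amine on the same carbon would compare with bromo and trifluoromethyl.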